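A few compounds are considered here, and "the series" means these few. Any claim that something is new, unique, unknown or untested is made for them only; others in the source may bear on it.

Compound 1, `c1cnc(NCCCNCC2CCc3ccccc3O2)nc1`, gives 1.59 nM in an assay on isolated protein (Bos taurus) with 5-hydroxytryptamine receptor 1D (Homo sapiens) as the target; on this read-out lower numbers stand for stronger inhibition and higher numbers for weaker inhibition.
Compound 2, `c1ccc2c(c1)CCC(CNCCCNC1=NCCCC1)O2`, gives 3.98 nM in this assay.
Compound 3, `c1ccc2c(c1)CCC(CNCCCNc1ccncn1)O2`, gives 10 nM in this assay.

Among the three measured compounds, compound 3 carries the highest number and so the weakest inhibition: the gaps to compound 2 and to compound 1 are both beyond the scatter, the nearer one being a 2.5-fold higher number from compound 2 to compound 3 (0.40 log units; beyond the scatter) and the wider one a 6.3-fold higher number from compound 1 to compound 3 (0.80 log units; beyond the scatter).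

Compound 4, `c1ccc2c(c1)CCC(CNCCCNc1cnccn1)O2`, is not yet measured. It differs from compound 3 in one place: pyrazin-2-yl in place of pyrimidin-4-yl on an amine nitrogen. All three measured steps bear on this change, since each swaps one six-membered group on the same amine nitrogen for another: a 2.5-fold higher number from compound 1 to compound 2 (0.40 log units; beyond the scatter), a 6.3-fold higher number from compound 1 to compound 3 (0.80 log units; beyond the scatter) and a 2.5-fold higher number from compound 2 to compound 3 (0.40 log units; beyond the scatter). Every such swap has shifted the number by a modest amount, never by more, and compound 3 sits at the weak end of that spread. A further ring swap of the same kind is therefore expected to move compound 4 by a modest step, more likely downward than upward given that compound 1 at 1.59 nM and compound 2 at 3.98 nM both lie below compound 3. The expected step is a 2.2-fold lower number from compound 3 to compound 4 (0.35 log units; beyond the scatter). Compound 4 is estimated at 4.5 nM in this assay, within a range from 1.5 nM to 14 nM.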

Compound 4, half-maximal inhibitory concentration: 10 nM
Estimate against measurement, compound 4: 2.2-fold (0.35 log units) below, and the stated range covers the measured number.
By their numbers in this assay, from the lowest: compound 1; then compound 2; then compounds 3 and 4 (each within the scatter of the next).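

In this assay, for the compounds shown here, pyrazin-2-yl in place of pyrimidin-4-yl on the amine nitrogen gives no change at the digits printed from compound 3 to compound 4 (within the scatter), the first swap at this position that stays within the scatter, and it exchanges two rings with the same atoms joined differently. Pyrimidin-2-yl remains apart from both of these groups, with a 6.3-fold higher number from compound 1 to compound 4 (0.80 log units; beyond the scatter) matching the gap already seen for compound 3. The non-aromatic ring of compound 2 also holds its place, with a 2.5-fold higher number from compound 2 to compound 4 (0.40 log units; beyond the scatter), so among these four compounds the number at this position does not simply follow whether the ring is aromatic.

Nothing available explains these differences. Still open, on these data alone, is where a pyridin-2-yl or a plain phenyl ring on this amine nitrogen would fall relative to compound 1 and compound 4, and whether the same order would hold with a longer chain.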